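Changing the end of the chain on an acylphenol core

The source may hold more compounds than are shown below. What is called first, only, known or untested is meant among the compounds shown, and "the series" means these compounds.

Measured so far:
compound 1, `CCCCCCCCCCCCCC(=O)c1c(O)cccc1OC`, 39000 nM
compound 2, `CCCCCCCCCCCCCC(=O)c1c(O)cccc1O`, 74100 nM

In an assay on isolated protein for inhibition of pancreatic alpha-amylase (Sus scrofa), with a stated time of 30 min (on this read-out lower numbers stand for stronger inhibition and higher numbers for weaker inhibition), compound 1 gives the lowest of the two numbers. Its nearest neighbour is compound 2, reached by a 1.9-fold higher number from compound 1 to compound 2 (0.28 log units; within the scatter), a hydrogen in place of a methyl on an oxygen on the aromatic ring; that step lies within the scatter, so the two numbers cannot be ordered.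

Compound 3, `COc1cccc(O)c1C(=O)CCCCCCCCc1ccc(O)cc1`, differs from compound 1 by 4-hydroxyphenyl in place of pentyl on a saturated chain carbon, eight bonds along the chain from a carbonyl carbon. Within the data shown here, no measured step touches the end of the chain: the only step known, a 1.9-fold higher number from compound 1 to compound 2 (0.28 log units; within the scatter), concerns the core and was within the scatter. There is therefore no basis for expecting a step beyond the scatter in this assay, and the estimate for compound 3 stays close to compound 1.

Compound 3 is expected to give 30000 nM, within 8000 nM to 120000 nM, an expected step of a 1.3-fold lower number from compound 1 to compound 3 (0.11 log units; within the scatter).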

Compound 3, half-maximal inhibitory concentration: 32300 nM
Compound 3: middle estimate off by 1.1-fold (0.03 log units), on the low side; the measured number falls inside the stated range.
By their numbers in this assay, from the lowest: compounds 3, 1 and 2 (each within the scatter of the next, the first and the last beyond it).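

At the end of the chain, 4-hydroxyphenyl in place of pentyl, on a saturated chain carbon, eight bonds along the chain from a carbonyl carbon, comes to a 1.2-fold lower number from compound 1 to compound 3 (0.08 log units; within the scatter) in this assay. Among these compounds, the earlier compounds differ only on the core, so this is the first sign that an open pentyl end can give way to a six-membered aromatic ring bearing a hydroxyl without a step beyond the scatter. No measurement at hand bears on why the exchange reads this way.

As far as these compounds go, how a plain phenyl, an amine or a carboxylic acid at the end of the chain, or a longer chain, would read in this assay remains open. Also open, from the compounds shown here alone, is whether hydrogen in place of methyl on the core's oxygen would stay within the scatter with 4-hydroxyphenyl at the chain end.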